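The source may hold more compounds than are shown below. What is called first, only, known or untested is meant among the compounds shown, and "the series" means these compounds.

Measured so far in an assay on cells for inhibition of Amine oxidase [flavin-containing] B (Homo sapiens), read by fluorescence and Amplex Red, with a stated time of 15 min; on this read-out higher numbers stand for weaker inhibition and lower numbers for stronger inhibition:

Compound 1, `Cc1ccc2cc(-c3ccc(Br)nn3)c(=O)oc2c1`: 750 nM
Compound 2, `COc1ccc2cc(-c3ccc(Br)nn3)c(=O)oc2c1`: 3050 nM
Compound 3, `Cc1cccc2cc(-c3ccc(Cl)nn3)c(=O)oc12`: 22700 nM

Compound 1 and compound 2 share a core and differ in one place, (methoxy in place of methyl on an aromatic carbon). That change brought a 4.1-fold higher number from compound 1 to compound 2 (0.61 log units; beyond the scatter). Compound 3 is built on a core of its own; the difference between the two cores is not broken down here. Among the three, compound 3 gives the highest number, and both of its gaps, to compound 2 and to compound 1, are beyond the scatter.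

Compound 4, `COc1cccc2cc(-c3ccc(Cl)nn3)c(=O)oc12`, has not yet been measured. It differs from compound 3 by methoxy in place of methyl on an aromatic carbon. Within the data shown here, this is the same kind of change as the one from compound 1 to compound 2, but not the same: in compound 1 the methyl sits meta to a fused ring and para to a fused ring, whereas in compound 3 it sits ortho to a fused ring and meta to a fused ring. Among the measured compounds shown here, only one example of this change has been measured, so the expectation rests on a single step made on a different core and at a different place.

Compound 4 is expected to follow the same direction as that single step, with an estimated step of a 2.6-fold higher number from compound 3 to compound 4 (0.42 log units; beyond the scatter) in this assay. Given that compound 3 already gives 22700 nM, compound 4 is estimated at 60000 nM, with a likely range from 20000 nM to 200000 nM.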

Compound 4, half-maximal inhibitory concentration: 30100 nM
Estimate against measurement, compound 4: 2.0-fold (0.30 log units) above, and the stated range covers the measured number.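

In this assay, methoxy in place of methyl on an aromatic carbon gave a 1.3-fold higher number from compound 3 to compound 4 (0.12 log units; within the scatter), a step that lies within the scatter, so on this core the change has no readable effect. Set beside the earlier step, the same change does not carry over in size from one core to the other: the same change on two cores in this assay, a 4.1-fold higher number (0.61 log units; beyond the scatter) from compound 1 to compound 2 and a 1.3-fold higher number (0.12 log units; within the scatter) from compound 3 to compound 4, 3.1-fold (0.49 log units) apart, beyond the scatter of two such steps. Among these compounds, this shows that, in this series, a step read on one core is a poor guide to its size on another, but it rests on only two pairs, which differ both in the core and in the place of the group, so it does not show which of these accounts for the gap or how the change would behave on a third core.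

The compounds shown leave open how other groups would fare at this place on the core of compound 3, such as a hydroxyl, an amine or a longer chain like ethoxy in place of the methoxy. They also leave open whether exchanging the chlorine of compound 3 for bromine, with nothing else changed, would move the number.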